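Quinoxalin-5-yl in place of quinolin-8-yl in compound 1

A few compounds are considered here, and "the series" means these few. Any claim that something is new, unique, unknown or untested is made for them only; others in the source may bear on it.

Compound 1 `O=C(N[C@H](/C=C/S(=O)(=O)c1ccccc1)CCc1ccccc1)c1cccc2cccnc12`: > 80000 nM (a limit, not a number)
Compound 2 `CC(C)C[C@@H](/C=C/S(=O)(=O)c1ccccc1)NC(=O)c1cccc2cccnc12`: 15100 nM

Both values come from an ADME assay on HepG2 cells (Homo sapiens) for cytotoxicity (a lower number here means that less compound is tolerated, a higher number that more compound is tolerated), and compound 1 stands at the limit of > 80000 nM in this assay, at which 1 of the 2 values shown sits, with no exact number. Compound 3 `O=C(N[C@H](/C=C/S(=O)(=O)c1ccccc1)CCc1ccccc1)c1cccc2nccnc12` carries quinoxalin-5-yl in place of quinolin-8-yl on a carbonyl carbon and otherwise matches compound 1. Going by the values given here, only one step has been measured (an at least 5.2-fold lower number from compound 1 to compound 2 (0.72 log units; beyond the scatter)) and it has isopropyl in place of benzyl on a saturated chain carbon, so it does not test this change. It shows that this assay can move on this series, but gives no size for a change on the carbonyl carbon. No step beyond the scatter is therefore expected, though this expectation rests on little. The expected step is an at least 1.1-fold lower number from compound 1 to compound 3 (0.05 log units; that floor lies within the scatter) in this estimate. For compound 3 the estimated value is 70000 nM (expected range 28000 nM to 150000 nM).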

Compound 3, half-maximal cytotoxic concentration: 39600 nM
Estimate against measurement, compound 3: 1.8-fold (0.25 log units) above, within the range that was stated.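

In this assay, going by these compounds alone, the change on the carbonyl carbon gives an at least 2.0-fold lower number from compound 1 to compound 3 (0.30 log units; that floor lies within the scatter) and is the first step at this position that can be read. Compound 3 gives 39600 nM as an exact number, which gives this position its first measured value. As far as these compounds go, the true size of the step remains unknown, because compound 1 stands at a limit and not at a number: the limit of > 80000 nM in this assay, at which 1 of the 3 values shown sits.

The compounds shown leave open whether the step from quinolin-8-yl to quinoxalin-5-yl really lies beyond the scatter, and whether the same change would give a similar step with the isopropyl group of compound 2 in place. They also leave open how this assay would respond to a quinoxalin-5-yl carrying an amine or a carboxylic acid.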